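Methyl replacement on the shared core: notes on compound 3

A few compounds are considered here, and "the series" means these few. Any claim that something is new, unique, unknown or untested is made for them only; others in the source may bear on it.

- compound 1 `COc1ccc(/C=C/C(=O)/C=C/c2nc3ccccc3n2C)cc1O`: 4800 nM
- compound 2 `COc1ccc(/C=C/C(=O)/C=C/c2nc3cc(C)ccc3n2C)cc1O`: 4800 nM
- compound 3 `COc1ccc(/C=C/C(=O)/C=C/c2nc3c(C)cccc3n2C)cc1O`: not yet measured

In a functional assay on SH-SY5Y cells (Homo sapiens) for cytotoxicity, read by MTT assay, with a stated time of 48 h (on this read-out lower numbers stand for stronger inhibition and higher numbers for weaker inhibition), compound 1 gives 4800 nM, level with compound 2 at 4800 nM. Compound 3 differs from compound 1 by methyl in place of hydrogen on an aromatic carbon. The only measured methyl replacement is no change at the digits printed from compound 1 to compound 2 (within the scatter). That single step sits on a different aromatic carbon and is thin support, yet no step beyond the scatter is expected in this assay. The estimated step is no change at the digits printed from compound 1 to compound 3 (within the scatter). Compound 3 is expected at 4800 nM, with an estimated range of 2200 nM to 10000 nM.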

Compound 3, half-maximal inhibitory concentration: 19100 nM
Compound 3: middle estimate off by 4.0-fold (0.60 log units), on the low side, outside the stated range (above it).
By their numbers in this assay, from the lowest: compounds 1 and 2 (each within the scatter of the next); then compound 3.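

Methyl in place of hydrogen gives a 4.0-fold higher number from compound 1 to compound 3 (0.60 log units; beyond the scatter) in this assay on this aromatic carbon of the shared core. On a different aromatic carbon, the same replacement gives no change at the digits printed from compound 1 to compound 2 (within the scatter) in that assay, so across these two cases the outcome depends on which aromatic carbon carries the methyl. Nothing available accounts for this difference.

Going by these compounds, whether a methoxy group, a chlorine atom or an amine on this carbon would also give a higher number remains open. A longer chain, such as ethyl, is likewise untested here.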